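The compounds below may be only part of what the source reports. "The series", "measured", "known", "first", "only" and "open" are said of these compounds alone.

Of the compounds shown here, two sharing one core have been tested so far. Compound 1 `NN1C(=O)/C(=C/c2c[nH]c3ccccc23)SC1=S` and compound 2 `O=C1NC(=O)/C(=C/c2c[nH]c3ccccc23)S1` were both examined in a functional assay on HL-60 cells (Homo sapiens) for cytotoxicity, read by MTT assay, with a stated time of 72 h; on this read-out higher numbers stand for weaker inhibition and lower numbers for stronger inhibition. In this assay compound 1 gives 3610 nM, and compound 2 gives 12800 nM. Compound 2 therefore stands at the higher of the two numbers, meaning it is the weaker inhibitor, and the gap to compound 1 lies beyond the usual scatter of repeated measurements.

Compound 3 `O=C1NC(=O)/C(=C/c2c[nH]c3ccc(Br)cc23)S1` has not yet been measured. It differs from compound 2 in a single place: bromo in place of hydrogen on an aromatic carbon. Among the compounds with values here, no measured pair shows the effect of such an exchange on this core, so an expectation can rest only on compound 2 and its value 12800 nM. A modest move toward a lower number is expected, on the order of the scatter itself, and the expected step from compound 2 to compound 3 is a 2.0-fold lower number from compound 2 to compound 3 (0.29 log units; within the scatter). For compound 3 in this assay the estimate is 6500 nM, with a range from 2000 nM to 20000 nM.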

Compound 3, half-maximal inhibitory concentration: > 50000 nM
Compound 3: no number, only a limit (the forecaster's own chance of this, stated with the estimate: 5%); at least 7.6-fold (0.88 log units) between middle value and limit.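

In this assay, this aromatic carbon of the six-membered ring of carbon only proves sensitive to substitution: bromo in place of hydrogen gives an at least 3.9-fold higher number from compound 2 to compound 3 (0.59 log units; beyond the scatter), so the change weakens inhibition rather than strengthening it. For compound 3, > 50000 nM is a limit of the assay and not a number, so this step gives only a minimum size for the change. The data on this compound consist of that limit alone and offer no cause for the change: the limit of > 50000 nM in this assay, at which 1 of the 3 values shown sits.

From the compounds shown here alone, it remains open whether fluoro, methoxy or an amine on this same carbon would also weaken inhibition, or whether any of them would keep it. Going by these compounds, it is equally open whether bromo would have the same effect on another carbon of this ring or on the core of compound 1.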